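This account rests on a few compounds, and the source may have more. Where it says the series, first, only, none or still open, it means among the compounds named here.

Compound 1, `O=C(CN1CCCC1)N1CCC(NS(=O)(=O)c2cc(S(=O)(=O)c3ccccc3)ccc2C(F)(F)F)CC1`: 110 nM
Compound 2, `CC(C)(C)OC(=O)N1C(=O)CC[C@H]1C(=O)N1CCC(NS(=O)(=O)c2cc(S(=O)(=O)c3ccccc3)ccc2C(F)(F)F)CC1`: 130 nM
Compound 3, `CN(C)CC(=O)N1CCC[C@H]1C(=O)N1CCC(NS(=O)(=O)c2cc(S(=O)(=O)c3ccccc3)ccc2C(F)(F)F)CC1`: 90 nM

These three compounds share one core and differ only in the group at one end. In an assay on isolated protein for binding affinity to secreted frizzled-related protein 1 (Homo sapiens), read by fluorescence (on this read-out higher numbers stand for weaker inhibition and lower numbers for stronger inhibition), compound 3 gives 90 nM, and against compound 1 and compound 2 its number lies within the usual scatter of both, so none of the three can be set apart.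

Compound 4, `O=C([C@@H]1CCCN1Cc1ccccc1)N1CCC(NS(=O)(=O)c2cc(S(=O)(=O)c3ccccc3)ccc2C(F)(F)F)CC1`, is not yet measured. It differs from compound 3 in one place: benzyl in place of ((dimethylamino)methyl)carbonyl on an amine nitrogen in a ring. Cut one bond further out, the same difference reads 1-(((dimethylamino)methyl)carbonyl)pyrrolidin-2-yl to 1-benzylpyrrolidin-2-yl.

For the measured compounds named here, only one measured step touches this region: a 1.2-fold lower number from compound 1 to compound 3 (0.09 log units; within the scatter), which exchanged the whole group at that end without moving the number beyond the scatter. Going by the values given here, no measured pair tests a benzyl there. A similar outcome is therefore expected: a 1.1-fold higher number from compound 3 to compound 4 (0.05 log units; within the scatter). In this assay compound 4 is estimated at 100 nM, with a range from 40 nM to 250 nM.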

Compound 4, half-maximal inhibitory concentration: 1400 nM
For compound 4 the middle estimate is 14-fold (1.15 log units) below the measured one; measured number outside the range, above it.
By their numbers in this assay, from the lowest: compounds 3, 1 and 2 (each within the scatter of the next); then compound 4.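

The end group of the shared core is not as forgiving as the first three compounds suggested. On the amine nitrogen in the ring, benzyl in place of ((dimethylamino)methyl)carbonyl gives a 16-fold higher number from compound 3 to compound 4 (1.19 log units; beyond the scatter) in this assay and the exchange of the whole end group gives a 13-fold higher number from compound 1 to compound 4 (1.10 log units; beyond the scatter) so this end can move the number well beyond the scatter. Nothing available explains this change. Still open, on these data alone, is whether the number follows the entering aromatic ring or the departing carbonyl; a benzoyl group or a plain methyl on that nitrogen would help separate the two.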